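Shortening the Butyl Chain on a Shared Core

The compounds below may be only part of what the source reports. "The series", "measured", "known", "first", "only" and "open" are said of these compounds alone.

Values in a functional assay on PC-3 cells (Homo sapiens) for cytotoxicity, read by MTT assay, with a stated time of 72 h; on this read-out lower numbers stand for stronger inhibition and higher numbers for weaker inhibition:
Compound 1, `[O-][n+]1nc(NCOCc2ccc(C(F)(F)F)cc2)[n+]([O-])c2ccccc21`: 9310 nM
Compound 2, `CCCCOCNc1n[n+]([O-])c2ccccc2[n+]1[O-]`: 6010 nM
Compound 3, `COc1ccc2c(c1)[n+]([O-])nc(NCOC(C)c1ccccc1)[n+]2[O-]`: > 100000 nM (a limit of the assay, not a number)

Three compounds share the same core and differ in the chain that hangs from the amine. Compound 1 and compound 2 give numbers that lie within the usual scatter of each other in this assay, so no difference between them can be claimed. Compound 3 gives only a limit in this assay, which means no number is available for it.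

Compound 4, `CCCOCNc1n[n+]([O-])c2ccccc2[n+]1[O-]`, has not yet been measured. It differs from compound 2 by hydrogen in place of methyl on a saturated chain carbon, three bonds along the chain from an oxygen on a saturated carbon; read one bond further out, butyl becomes propyl. Going by the values given here, no measured pair in this set shows the effect of such a change, so the expectation rests on the closeness of compound 1 and compound 2 alone.

The step from compound 2 to compound 4 is expected to be a 1.2-fold higher number from compound 2 to compound 4 (0.07 log units; within the scatter), nothing beyond the scatter in either direction. Compound 4 is therefore estimated at 7000 nM in this assay, with a range from 3000 nM to 17000 nM.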

Compound 4, half-maximal inhibitory concentration: 7400 nM
Compound 4: middle estimate off by 1.1-fold (0.02 log units), on the low side; the measured number falls inside the stated range.
By their numbers in this assay, from the lowest: compounds 2, 4 and 1 (each within the scatter of the next). At a limit, above all of these: compound 3.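

In this assay, going by these compounds alone, the change from butyl to propyl gives a 1.2-fold higher number from compound 2 to compound 4 (0.09 log units; within the scatter), and this is the first measured pair here that differs in one place only, so the first direct reading of a change on a saturated chain carbon, three bonds along the chain from an oxygen on a saturated carbon. Hydrogen can stand in place of methyl at this position with no difference that can be claimed, so butyl and propyl cannot be told apart in this assay. Nothing measured here says why the two chains read alike, and one pair supports no wider rule about the chain.

The compounds shown leave open whether a much shorter chain such as ethyl, a longer chain such as hexyl, or an amine or a carboxylic acid at the end of the chain would still give numbers at this level. They also leave open whether the same step from butyl to propyl would read the same way on a version of the shared core that carries a fluorine.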